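A few compounds are considered here, and "the series" means these few. Any claim that something is new, unique, unknown or untested is made for them only; others in the source may bear on it.

Compound 1 `C=CCSc1nnc(CC)n1N1C(=O)c2ccccc2C1=O` is the reference point of this small set. In a functional assay on A549 cells (Homo sapiens) for cytotoxicity, read by MTT assay, with a stated time of 48 h (a higher number here means a weaker inhibitor, a lower number a stronger inhibitor), compound 1 gives only a limit of the assay, > 200000 nM. Compound 2 `CCc1nnc(SCC(=O)c2ccc(Cl)cc2)n1N1C(=O)c2ccccc2C1=O` also reaches only a limit in this assay, > 200000 nM. Compound 3 `CCOC(=O)CSc1nnc(CC)n1N1C(=O)c2ccccc2C1=O` likewise gives only a limit in this assay, > 200000 nM. The steps a step that the two limits leave unreadable from compound 1 to compound 2, a step that the two limits leave unreadable from compound 1 to compound 3 and a step that the two limits leave unreadable from compound 2 to compound 3 therefore cannot be sized; what the three share is the limit of > 200000 nM in this assay, at which 3 of the 3 values shown sit. Compound 4 `C=CCSc1nnc(CCC)n1N1C(=O)c2ccccc2C1=O` differs from compound 1 by methyl in place of hydrogen on a saturated chain carbon, two bonds along the chain from an aromatic carbon. Among the measured compounds shown here, none of the measured steps touches this position, and every measured value sits at the limit, so no readable step bears on the change and no direction can be drawn from the numbers. For compound 4 the expectation in this assay is therefore a value again at or beyond the same limit, with the step that the limit leaves unreadable from compound 1 to compound 4 expected to stay within the scatter. Compound 4 is estimated at 300000 nM, in a range from 100000 nM to 2000000 nM.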

Compound 4, half-maximal inhibitory concentration: > 200000 nM
Compound 4: only a limit was reported; the forecaster's own chance of this, stated with the estimate: 85%; the middle value is on the limit's open side.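

No step can be read from compound 1 to compound 4, since both compounds, like compounds 2 and 3, give only a limit: the limit of > 200000 nM in this assay, at which 4 of the 4 values shown sit. The compounds shown leave open how large any step in this assay is and which change to the shared core, if any, gives a value inside that limit.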